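A few compounds are considered here, and "the series" means these few. Any claim that something is new, unique, unknown or untested is made for them only; others in the source may bear on it.

Compound 1 `CC1(C)CCCC2=CC=C(C=O)CC[C@]21C`: 138000 nM
Compound 2 `C#CC1=CC[C@]2(CC1)C(=C)CC[C@H]2C(C)C`: 103000 nM
Compound 3 `C=C1CCC[C@]2(C)CCC(c3cn(-c4ccc(OC)cc4)nn3)=CC[C@@]12C`: 34700 nM

In a functional assay on A549 cells (Homo sapiens) for cytotoxicity, read by MTT assay, with a stated time of 48 h (on this read-out lower numbers stand for stronger inhibition and higher numbers for weaker inhibition), compound 3 gives the lowest of the three numbers. Its gap to compound 2 is beyond the scatter, and its gap to compound 1 is wider still, so compound 3 is the strongest of the measured set. Among the compounds with values here, no pair of measured compounds differs in a single place, so no reference step exists for the move to compound 4 `C=C1CCC[C@]2(C)CCC(c3cn(-c4cccc(OC)c4)nn3)=CC[C@@]12C`. The change is 3-methoxyphenyl in place of 4-methoxyphenyl on an aromatic nitrogen The two compounds hold the same atoms, joined differently, the exchange sitting on an aromatic nitrogen of a five-membered aromatic ring with 3 nitrogen. With nothing comparable at hand, the expected step is small, of no set direction, and within the scatter. Compound 4 is expected near 36000 nM, with a range from 15000 nM to 85000 nM. The implied step is expected to be a 1.0-fold higher number from compound 3 to compound 4 (0.02 log units; within the scatter).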

Compound 4, half-maximal inhibitory concentration: 11200 nM
For compound 4 the middle estimate is 3.2-fold (0.51 log units) above the measured one; measured number outside the range, below it.
By their numbers in this assay, from the lowest: compound 4; then compound 3; then compounds 2 and 1 (each within the scatter of the next).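

In this assay, 3-methoxyphenyl in place of 4-methoxyphenyl on the aromatic nitrogen gives a 3.1-fold lower number from compound 3 to compound 4 (0.49 log units; beyond the scatter). Within the data shown here, this is the first single-place step, and it shows that with the same atoms, joined differently, this position still responds beyond the scatter. No measurement on hand accounts for the step.

Open, as far as these compounds go, is how this position responds when the methoxy group gives way to a hydroxyl or the methoxyphenyl to an unsubstituted phenyl or a pyridine. Also open, from the compounds shown here alone, is whether an amine or a carboxylic acid on the phenyl ring would be tolerated.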